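The source may report more compounds than this note shows. Statements on the series, on what has been measured and on what is new or still open speak of the compounds shown alone.

In a functional assay on A549 cells (Homo sapiens) for cytotoxicity, read by MTT assay, with a stated time of 72 h (a lower number here means a stronger inhibitor, a higher number a weaker inhibitor), compound 1 `C#Cc1cccc(Nc2ncnc3oc(C)c(C(=O)OCC)c23)c1` gives only a limit, > 1000000 nM. Compound 3 `Cc1oc2ncnc(Nc3cccc(Cl)c3)c2c1C(=O)NCCO` also gives only a limit, > 1000000 nM. Among the measured compounds shown here, compound 2 `CCOC(=O)c1c(C)oc2ncnc(Nc3ccc(OCc4cccc(Cl)c4)cc3)c12` gives 513000 nM, the only actual number in the set, which is otherwise defined by the limit of > 1000000 nM in this assay, at which 2 of the 3 values shown sit. Compound 4 `CCOC(=O)c1c(C)oc2ncnc(Nc3ccccc3)c12` differs from compound 2 in one place, with hydrogen in place of (3-chlorobenzyl)oxy on an aromatic carbon. For the measured compounds named here, no measured pair isolates this change, but compound 1 and compound 3 also lack (3-chlorobenzyl)oxy and neither gave a number. A modest move towards weaker inhibition is therefore expected, with an estimated step of a 1.6-fold higher number from compound 2 to compound 4 (0.19 log units; within the scatter), and the assay may report only a limit. For compound 4 the estimated value is 800000 nM, with an expected range of 350000 nM to 1800000 nM.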

Compound 4, half-maximal inhibitory concentration: > 1000000 nM
Compound 4: a limit, no number; the forecaster's own chance of this, stated with the estimate: 60%; at least 1.2-fold (0.09 log units) between middle value and limit.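

Among the compounds shown here, with hydrogen in place of (3-chlorobenzyl)oxy on an aromatic carbon, this assay now gives a first comparison at this position: an at least 1.9-fold higher number from compound 2 to compound 4 (0.28 log units; that floor lies within the scatter). Going by these compounds, compound 4 gives a limit and not a number, so the true size of this step stays unknown. The step between compound 1 and compound 4 cannot be read, as both values are limits, and the set remains largely pinned to one limit: the limit of > 1000000 nM in this assay, at which 3 of the 4 values shown sit.

On these data alone, it remains open whether a plain benzyloxy or a methoxy at this position would give a number. As far as these compounds go, whether the chlorine of compound 2 matters also remains open.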